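The compounds below may be only part of what the source reports. "The series", "measured", "known", "first", "only" and "open" are said of these compounds alone.

Measured in a functional assay on A549 cells (Homo sapiens) for antiproliferative activity, read by MTT assay, with a stated time of 72 h; on this read-out lower numbers stand for stronger inhibition and higher numbers for weaker inhibition:
compound 1 `CCCSc1nc(Cl)c2c(n1)N(Cc1ccccc1)C(C(=O)NCCC1=CCc3ccccc31)N2` gives 48800 nM
compound 2 `CCCSc1nc(Cl)c2c(n1)N(Cc1ccccc1)C(C(=O)NCC(C)C)N2` gives 48200 nM
compound 3 `CCCSc1nc(Cl)c2c(n1)N(Cc1ccccc1)C(C(=O)OCC)N2` gives 13800 nM

Among these three numbers compound 3 has the lowest; compound 2 and compound 1 both sit at higher numbers, and both gaps lie beyond the scatter. Compound 4 `CCCSc1nc(Cl)c2c(n1)N(Cc1ccccc1)C(C(=O)NCCCc1ccccc1)N2` differs from compound 3 in one place: (3-phenylpropyl)amino in place of ethoxy on a carbonyl carbon. Among the compounds with values here, two measured steps bear on this change. The step of a 3.5-fold lower number from compound 2 to compound 3 (0.54 log units; beyond the scatter) is the same kind of exchange run the other way, ethoxy replacing isobutylamino on the carbonyl carbon. The step of a 1.0-fold lower number from compound 1 to compound 2 (0.01 log units; within the scatter) shows that exchanging one group on the amide-type nitrogen for another of quite different size changed little. For compound 4 the expected step back toward the amide numbers is therefore a 3.3-fold higher number from compound 3 to compound 4 (0.51 log units; beyond the scatter). Compound 4 is estimated at 45000 nM, with a range from 20000 nM to 100000 nM.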

Compound 4, half-maximal inhibitory concentration: 9430 nM
Compound 4: the middle estimate sits 4.8-fold (0.68 log units) above what was measured, outside the stated range (below it).
By their numbers in this assay, from the lowest: compounds 4 and 3 (each within the scatter of the next); then compounds 2 and 1 (each within the scatter of the next).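

In this assay, an amide on the carbonyl carbon need not give a higher number than the ester, as (3-phenylpropyl)amino and ethoxy remain within the scatter of each other (a 1.5-fold lower number from compound 3 to compound 4 (0.17 log units; within the scatter)). The group on the amide nitrogen also matters more than the earlier amides suggested: compound 4 stands clearly apart from both (a 5.1-fold lower number from compound 2 to compound 4 (0.71 log units; beyond the scatter); a 5.2-fold lower number from compound 1 to compound 4 (0.71 log units; beyond the scatter)), though compound 1 and compound 2 lie within the scatter of each other. No measurement here gives a reason for this. As far as these compounds go, whether the phenyl ring, the chain length or both matter remains open. Benzylamino or (5-phenylpentyl)amino would test this further.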